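Chain branching in the alkoxy arm: from neopentyl to pentan-3-yl

A few compounds are considered here, and "the series" means these few. Any claim that something is new, unique, unknown or untested is made for them only; others in the source may bear on it.

Measured so far in an assay on THP-1 cells for inhibition of nuclear factor NF-kappa-B complex (Homo sapiens), with stated times of 2 h and 16 h; a higher number here means a weaker inhibitor, a lower number a stronger inhibitor:
compound 1, `CC(C)CCCOc1cccc(O)c1C(=O)/C=C/c1ccc(O)cc1`, gives 11000 nM
compound 2, `CC(C)(C)CCOc1cccc(O)c1C(=O)/C=C/c1ccc(C(=O)O)cc1`, gives 2800 nM
compound 3, `CC(C)(C)CCOc1cccc(O)c1C(=O)/C=C/c1ccc(O)cc1`, gives 3000 nM

Compound 3 sits second highest of the three numbers. Its nearest neighbour is compound 2, and a 1.1-fold higher number from compound 2 to compound 3 (0.03 log units; within the scatter), so the two are not separable. Compound 1 is the outlier, with a 3.7-fold lower number from compound 1 to compound 3 (0.56 log units; beyond the scatter). That step, a rearrangement of the same carbon count from isobutyl to tert-butyl two bonds along the chain from the aryl oxygen, is the only one in the set that speaks to chain shape, and it is modest.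

Compound 4, `CCC(CC)COc1cccc(O)c1C(=O)/C=C/c1ccc(O)cc1`, is the next rearrangement of the same five-carbon chain: pentan-3-yl in place of neopentyl on a saturated chain carbon bound to an oxygen on an aromatic ring. For the measured compounds named here, no measured pair reports this particular shift of branching toward the oxygen-bearing carbon; the only comparable step, from compound 1 to compound 3, shows that rearranging the chain can move the number beyond the scatter but not by much. Going by the values given here, with no closer precedent, a small shift in either direction or none is the reasonable expectation, and the estimate for compound 4 is therefore kept near compound 3 with a wide range. The expected step is a 1.3-fold higher number from compound 3 to compound 4 (0.12 log units; within the scatter), and the estimated value for compound 4 in this assay is 4000 nM, with a range from 1500 nM to 11000 nM.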

Compound 4, half-maximal inhibitory concentration: 12000 nM
The estimate for compound 4 lay 3.0-fold (0.48 log units) below the measured number; the measured number lies above the stated range.
By their numbers in this assay, from the lowest: compounds 2 and 3 (each within the scatter of the next); then compounds 1 and 4 (each within the scatter of the next).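

In this assay, the swap of neopentyl for pentan-3-yl on a saturated chain carbon bound to an oxygen on an aromatic ring is not neutral, even though both groups have the same heavy-atom count and the rest of the molecule is unchanged (the step is a 4.0-fold higher number from compound 3 to compound 4 (0.60 log units; beyond the scatter) and lies beyond the scatter). The two other chain shapes cannot be separated (the step is a 1.1-fold higher number from compound 1 to compound 4 (0.04 log units; within the scatter) and lies within the scatter), so among the hydroxy compounds the 3,3-dimethylbutoxy arm of compound 3 stands apart, while the 2-ethylbutoxy arm of compound 4 and the arm of compound 1 read alike. No supporting data bear on the reason for this difference in this assay.

Going by these compounds, the carboxy for hydroxy exchange is read only with the neopentyl arm, so whether it is equally silent with the pentan-3-yl arm remains open. Also open, on these data alone, is how this assay's number would respond to a longer chain such as n-hexyl, a cyclohexylmethyl group, or an amine at the end of the arm.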